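This account rests on a few compounds, and the source may have more. Where it says the series, first, only, none or still open, it means among the compounds named here.

Compound 1 `Cc1[nH]ncc1-c1cncc(-c2ccc(C(N)=O)c(OC(C)C)c2)c1` is the reference point of this pair. In an assay on HeLa cells for inhibition of MAP kinase-interacting serine/threonine-protein kinase 1/2 (Homo sapiens), read by AlphaScreen, with a stated time of 2 h (on this read-out higher numbers stand for weaker inhibition and lower numbers for stronger inhibition), compound 1 gives 320 nM, the lowest of the two numbers recorded so far. Going by the values given here, its only measured neighbour, compound 2 `CC(C)Oc1cc(-c2cncc(-c3cnn(C(C)C)c3)c2)ccc1C(N)=O`, gives 940 nM in this assay, and the step of a 2.9-fold higher number from compound 1 to compound 2 (0.47 log units; beyond the scatter) is the one comparison available. That step exchanged the whole substituent on the five-membered ring, so it bears only loosely on the change now at hand.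

Compound 3 `Cc1n[nH]c(C)c1-c1cncc(-c2ccc(C(N)=O)c(OC(C)C)c2)c1` differs from compound 1 in one place: methyl in place of hydrogen on an aromatic carbon. The ring keeps its nitrogen-bound hydrogen and its first methyl; a second methyl simply enters on the other carbon flanking the substituted one. Among the compounds with values here, no measured step isolates such an addition, and the step from compound 1 to compound 2 tells more about the nitrogen substitution than about a methyl on carbon.

With so little to go on, compound 3 is expected to sit close to compound 1, the step of a 1.3-fold higher number from compound 1 to compound 3 (0.10 log units; within the scatter) being estimated as within or just beyond the scatter, in either direction. Compound 3 is estimated at 400 nM, with a range from 150 nM to 1100 nM.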

Compound 3, half-maximal inhibitory concentration: 160 nM
For compound 3 the middle estimate is 2.5-fold (0.40 log units) above the measured one; low and high end bracket the measured number.
By their numbers in this assay, from the lowest: compounds 3 and 1 (each within the scatter of the next); then compound 2.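

In this assay, a methyl is accepted on the aromatic carbon next to the ring nitrogen and next to the ring atom that bears a large group: in going from 5-methyl-1H-pyrazol-4-yl to 3,5-dimethyl-1H-pyrazol-4-yl, the result is a 2.0-fold lower number from compound 1 to compound 3 (0.30 log units; within the scatter), so the two compounds cannot be told apart on this read-out. The other new comparison, a 5.9-fold lower number from compound 2 to compound 3 (0.77 log units; beyond the scatter), shows that compound 1 and compound 3, which both keep the nitrogen-bound hydrogen and carry methyl on carbon, each stand clearly apart from compound 2, although that step exchanges the whole substituent and not one methyl alone. Nothing measured here explains these numbers, and no supporting data on the compounds are at hand.

As far as these compounds go, whether the gap to compound 2 goes with the isopropyl on the ring nitrogen or with the absence of methyl on the ring carbons stays open, since that step changes both at once. Also open, from the compounds shown here alone, is what a group other than methyl, such as an ethyl, a methoxy or an amine, would give on this same carbon.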